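This account rests on a few compounds, and the source may have more. Where it says the series, first, only, none or still open, it means among the compounds named here.

The study so far holds two measured compounds, compound 1 `Cc1ccc(S(=O)(=O)n2cc(-c3cc(C(F)(F)F)cc(-c4cn(S(=O)(=O)c5ccc(C)cc5)c5cc(Br)ccc45)n3)c3ccc(Br)cc32)cc1` and compound 2 `COc1ccc2c(c1)c(-c1cc(C(F)(F)F)ccn1)cn2S(=O)(=O)c1ccc(C)cc1`. In a functional assay on A549 cells (Homo sapiens) for inhibition, tested at 100 uM (a lower number here means a weaker effect, a higher number a stronger effect of the compound at the concentration tested), compound 1 gives 49.2%, the higher of the two numbers recorded. In this assay compound 2 gives 35.9%, a value that falls below that of compound 1 by more than the usual scatter. The two compounds differ from each other in several places at once, so no single structural step can be read from their pair.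

The unmeasured compound is compound 3 `Cc1ccc(S(=O)(=O)n2cc(-c3cc(C(F)(F)F)c(C#N)c(-c4cn(S(=O)(=O)c5ccc(C)cc5)c5cc(Br)ccc45)n3)c3ccc(Br)cc32)cc1`. It differs from compound 1 in one place only: cyano in place of hydrogen on an aromatic carbon. Among the compounds with values here, no pair of measured compounds shows what such a change does in this assay, so there is no measured step to lean on. In the absence of such a precedent the expected step of a number 0.8 percentage points higher from compound 1 to compound 3 (within the scatter) is small, with no clear direction, and is expected to stay within the usual scatter of the assay. For compound 3 the estimated value in this assay is 50%, with an expected range from 30% to 70%.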

Compound 3, a percentage reported as inhibition, at one concentration (the size of the read-out at that concentration, not a potency): 48.1%
Compound 3: middle estimate off by 1.9 percentage points, on the high side; low and high end bracket the measured number.
By their numbers in this assay, from the lowest: compound 2; then compounds 3 and 1 (each within the scatter of the next).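

In this assay, cyano in place of hydrogen on an aromatic carbon gives a number 1.1 percentage points lower from compound 1 to compound 3 (within the scatter) and so does not move the read-out beyond the usual scatter. Within the data shown here, this gives a first reading of this position, which lies on the six-membered aromatic ring with one nitrogen, ortho to a trifluoromethyl group and two atoms from the ring nitrogen: a nitrile can stand here, ortho to one large group and para to another, while the read-out of compound 3 remains indistinguishable from that of compound 1. Among these compounds, compound 1 and compound 2 differ in several places at once, so this is the only single-place step available, and nothing measured here accounts for the result.

The compounds shown leave open whether a different group at this same carbon, such as an amine, a carboxylic acid or a longer alkyl chain, would shift the read-out beyond the scatter. They also leave open whether cyano would behave in the same way on the core of compound 2, which carries a single substituted indole-free arrangement of its own.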